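Swapping the benzyl substituent pattern on compound 3

The source may hold more compounds than are shown below. What is called first, only, known or untested is meant among the compounds shown, and "the series" means these compounds.

Among the three compounds measured, compound 3 `CCCn1c(=O)c2nc(-c3cnn(Cc4cc(C(F)(F)F)ccc4Cl)c3)[nH]c2n(CCC)c1=O` shows the lowest number in an in vitro assay on HEK293 cells for displacement of a labelled ligand from adenosine receptor A2b (Homo sapiens) (a lower number here means a stronger inhibitor, a higher number a weaker inhibitor), giving 22 nM. Its nearest neighbour is compound 1 `CCCn1c(=O)c2nc(-c3cnn(Cc4cc(Cl)ccc4Cl)c3)[nH]c2n(CCC)c1=O`, which in this assay gives 29 nM; the gap between them, a 1.3-fold lower number from compound 1 to compound 3 (0.12 log units; within the scatter), stays within the scatter. Compound 2 `CCCn1c(=O)c2nc(-c3cnn(Cc4ccc(F)cc4F)c3)[nH]c2n(CCC)c1=O` gives 700 nM and sits far away: the step of a 32-fold lower number from compound 2 to compound 3 (1.50 log units; beyond the scatter) is large.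

Compound 4 `CCCn1c(=O)c2nc(-c3cnn(Cc4c(F)cccc4F)c3)[nH]c2n(CCC)c1=O` differs from compound 3 by 2,6-difluorophenyl in place of 2-chloro-5-(trifluoromethyl)phenyl on a saturated chain carbon bound to an aromatic nitrogen. Going by the values given here, two measured steps bear on this change, since both replace a phenyl carrying chloro and either chloro or trifluoromethyl with one carrying two fluorines: a 24-fold higher number from compound 1 to compound 2 (1.38 log units; beyond the scatter) and a 32-fold lower number from compound 2 to compound 3 (1.50 log units; beyond the scatter). Both were large and both ran in the direction of a weaker inhibitor whenever the difluoro pattern was present. Among the compounds with values here, no measured compound carries the 2,6-difluorophenyl itself, so the exact size is uncertain, but a large rise in the number is expected.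

Compound 4 is therefore estimated to give 400 nM in this assay, with a range from 100 nM to 2000 nM, an expected step of an 18-fold higher number from compound 3 to compound 4 (1.26 log units; beyond the scatter) from compound 3.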

Compound 4, inhibition constant: 390 nM
Estimate against measurement, compound 4: 1.0-fold (0.01 log units) above; the range from low to high includes it.
By their numbers in this assay, from the lowest: compounds 3 and 1 (each within the scatter of the next); then compounds 4 and 2 (each within the scatter of the next).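

At this place, on a saturated chain carbon bound to an aromatic nitrogen, the 2,6-difluorophenyl group in this assay gives an 18-fold higher number from compound 3 to compound 4 (1.25 log units; beyond the scatter) and a 13-fold higher number from compound 1 to compound 4 (1.13 log units; beyond the scatter), so a second difluoro pattern now stands well apart from both chlorine-bearing groups. The earlier compounds offered only one difluoro pattern, whereas the step between the two patterns, a 1.8-fold lower number from compound 2 to compound 4 (0.25 log units; within the scatter), shows that 2,6-difluorophenyl in place of 2,4-difluorophenyl makes no difference beyond the scatter; among these four compounds, none goes against this split between the two chlorine-bearing and the two difluoro groups. No supporting data are available to explain the split.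

The compounds shown leave open whether the split follows the presence of chloro, the presence of two fluorines, or the particular pairing of substituents on the phenyl ring. A plain phenyl, a 2,6-dichlorophenyl or a phenyl carrying one chloro and one fluoro at this place would bear on that question, and a methoxy group on the ring would show whether substituents other than halogens and trifluoromethyl can match compound 3.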